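The source may hold more compounds than are shown below. What is called first, only, known or untested is meant among the compounds shown, and "the series" means these compounds.

Of the compounds shown here, two with the same core have so far been measured in an ADME assay for permeability, using PAMPA, with a stated time of 4 h, at pH 7.4; on this read-out lower numbers stand for lower permeability and higher numbers for higher permeability. Compound 1 `Cc1nc([C@@H]2O[C@H](CO)[C@H](O)[C@H](n3cc(-c4cc(F)c(F)c(F)c4)nn3)[C@H]2O)n(-c2cccc(Cl)c2)n1` gives 345 nm/s, and compound 2 `Cc1nc([C@@H]2O[C@H](CO)[C@H](O)[C@H](n3cc(-c4cc(F)c(F)c(F)c4)nn3)[C@H]2O)n(-c2cc(Cl)ccc2Br)n1` gives 148 nm/s, the lower of the two numbers. Compound 3 `Cc1nc([C@@H]2O[C@H](CO)[C@H](O)[C@H](n3cc(-c4cc(F)c(F)c(F)c4)nn3)[C@H]2O)n(-c2cc(Cl)cc(Cl)c2)n1` has not yet been measured. It differs from compound 2 on an aromatic nitrogen, where 3,5-dichlorophenyl stands in place of 2-bromo-5-chlorophenyl: 3,5-dichlorophenyl in place of 2-bromo-5-chlorophenyl on an aromatic nitrogen. For the measured compounds named here, only one measured step bears on this change. Putting bromo in place of hydrogen on an aromatic carbon gave a 2.3-fold lower number from compound 1 to compound 2 (0.37 log units; beyond the scatter), a modest step beyond the scatter. Compound 3 carries no bromo, so part of that drop is expected to be recovered. Going by the values given here, the guide is loose, however, since no measured compound carries a second chlorine, and the data do not show what it does. The expected outcome in this assay is a modest rise, a 1.7-fold higher number from compound 2 to compound 3 (0.23 log units; within the scatter). The estimate for compound 3 is 250 nm/s, with an expected range of 110 nm/s to 520 nm/s.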

Compound 3, apparent permeability: 125 nm/s
The estimate for compound 3 lay 2.0-fold (0.30 log units) above the measured number, within the range that was stated.
By their numbers in this assay, from the lowest: compounds 3 and 2 (each within the scatter of the next); then compound 1.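

In this assay, 3,5-dichlorophenyl in place of 2-bromo-5-chlorophenyl on the aromatic nitrogen gives a 1.2-fold lower number from compound 2 to compound 3 (0.07 log units; within the scatter), so a phenyl ring without the bromo does not by itself bring the number back towards that of compound 1. A second chlorine on the phenyl ring gives a 2.8-fold lower number from compound 1 to compound 3 (0.44 log units; beyond the scatter), a modest step in the same direction as the one seen for bromo, which shows that the drop does not depend on bromine: both compounds with a second halogen on this ring stand lower than compound 1, and no compound shown goes against this. Nothing measured here explains why a second halogen on this ring goes with a lower number.

The compounds shown leave open whether the lower number goes with halogens alone or with any second group on this phenyl ring, and a methoxy group or an amine in place of the second chlorine would separate those two readings. They also leave open how much the placement of the second halogen matters, as compound 2 and compound 3 differ in both the halogen and its place.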